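The compounds below may be only part of what the source reports. "The series", "measured", "known", "first", "only" and "open" are said of these compounds alone.

Compounds measured so far in an assay on HEK293 cells for agonist activity at transient receptor potential cation channel subfamily M member 8 (Homo sapiens), read by fluorescence and calcium flux, with a stated time of 15 min; a lower number here means that less compound is needed, a higher number that more compound is needed for the effect:
compound 1 `Cc1ccc(OCC(=O)N(Cc2cccs2)c2ccnn2C)cc1`, 422 nM
compound 2 `Cc1ccc(OCC(=O)N(Cc2cccs2)c2ccncc2)cc1`, 52 nM

Among the measured compounds shown here, compound 2 gives the lowest of the two numbers in this assay; its only neighbour is compound 1, which lies an 8.1-fold lower number from compound 1 to compound 2 (0.91 log units; beyond the scatter) away. Compound 3 `Cc1ccc(OCC(=O)N(Cc2cccs2)c2nccn2C)cc1` has not been measured. It differs from compound 2 in one place: 1-methyl-1H-imidazol-2-yl in place of pyridin-4-yl on an amide-type nitrogen. For the measured compounds named here, the one step that bears on this change is the step of an 8.1-fold lower number from compound 1 to compound 2 (0.91 log units; beyond the scatter), in which a five-membered ring with two hetero atoms and a methyl on nitrogen gave way to pyridin-4-yl. The change to compound 3 reverses that kind of exchange, bringing back a five-membered ring with two hetero atoms and a methyl on nitrogen, though as 1-methyl-1H-imidazol-2-yl rather than 1-methyl-1H-pyrazol-5-yl. Compound 3 is therefore expected to give a higher number than compound 2, by a step of about a 4.2-fold higher number from compound 2 to compound 3 (0.63 log units; beyond the scatter), well beyond the scatter. The estimate for compound 3 in this assay is 220 nM, with a range from 60 nM to 800 nM.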

Compound 3, half-maximal effective concentration: 1790 nM
Compound 3: middle estimate off by 8.1-fold (0.91 log units), on the low side, outside the stated range (above it).
By their numbers in this assay, from the lowest: compound 2; then compound 1; then compound 3.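

In this assay, the group on the amide-type nitrogen turns out to matter by more than its ring size: 1-methyl-1H-imidazol-2-yl in place of pyridin-4-yl gives a 34-fold higher number from compound 2 to compound 3 (1.54 log units; beyond the scatter), a large step. The two five-membered rings also do not read alike, since 1-methyl-1H-imidazol-2-yl in place of 1-methyl-1H-pyrazol-5-yl gives a 4.2-fold higher number from compound 1 to compound 3 (0.63 log units; beyond the scatter), although each ring carries two hetero atoms and a methyl on nitrogen. Nothing in the data given here accounts for either step.

The compounds shown leave open how a phenyl or a pyrimidinyl group would compare with pyridin-4-yl on this nitrogen. They also leave open whether an ethyl in place of the methyl on the imidazole ring would shift the number, and whether the same order holds with the rest of the shared core changed.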